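This account rests on a few compounds, and the source may have more. Where it says the series, first, only, none or still open, it means among the compounds named here.

In a functional assay on HeLa S3 cells (Homo sapiens) for antiproliferative activity, read by XTT assay, with a stated time of 72 h (a higher number here means a weaker inhibitor, a lower number a stronger inhibitor), compound 3 (`COc1nc(N)nc2c1c(-c1cccs1)cn2[C@@H]1O[C@H](CO)[C@@H](O)[C@H]1O`) stands at > 20000 nM, which is a limit of the assay and not a number. Compound 2 (`COc1nc(N)nc2c1c(-c1ccco1)cn2[C@@H]1O[C@H](CO)[C@@H](O)[C@H]1O`) gives > 20000 nM, likewise only a limit. Compound 1 (`Nc1nc(N)c2c(-c3ccsc3)cn([C@@H]3O[C@H](CO)[C@@H](O)[C@H]3O)c2n1`), which carries thiophen-3-yl on a different core, gives > 20000 nM, again only a limit. The whole picture so far is the limit of > 20000 nM in this assay, at which 3 of the 3 values shown sit.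

Compound 4 (`COc1nc(N)nc2c1c(-c1ccsc1)cn2[C@@H]1O[C@H](CO)[C@@H](O)[C@H]1O`) has thiophen-3-yl in place of thiophen-2-yl on an aromatic carbon of the shared core: thiophen-3-yl in place of thiophen-2-yl on an aromatic carbon.

Within the data shown here, the one measured step that bears on this change is a step that the two limits leave unreadable from compound 2 to compound 3. Among the measured compounds shown here, it has no size that could be carried over, and no measured compound has yet given a number. No step beyond the scatter is therefore expected in this assay, and no direction can be expected either. The expected step is a step that the limit leaves unreadable from compound 3 to compound 4. For compound 4 the estimate is 25000 nM, with an expected range from 10000 nM to 50000 nM, and the assay is expected most probably to report only a limit again.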

Compound 4, half-maximal inhibitory concentration: > 20000 nM
Compound 4: no number, only a limit; the forecaster's own chance of this, stated with the estimate: 90%; the middle value does not contradict the limit.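

In this assay, among these compounds, compound 4 gives only a limit, as do compound 1, compound 2 and compound 3, so no step to compound 4 can be read: the limit of > 20000 nM in this assay, at which 4 of the 4 values shown sit. The compounds shown leave open whether thiophen-3-yl, thiophen-2-yl and furan-2-yl on the shared core differ at all in this assay.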